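The source may hold more compounds than are shown below. What is called first, only, known or untested is meant among the compounds shown, and "the series" means these compounds.

Measured in a functional assay on RS4-11 cells (Homo sapiens) for inhibition, read by CCK-8 assay, with a stated time of 48 h; on this read-out higher numbers stand for weaker inhibition and lower numbers for stronger inhibition:
- compound 1 `COc1ccc(S(=O)(=O)Oc2ccccc2/C=C(\C#N)C(=O)Nc2nnc(-c3cccs3)s2)cc1`: 4750 nM
- compound 2 `Cc1ccc(S(=O)(=O)Oc2cccc(/C=C(\C#N)C(=O)Nc3nnc(-c4cccs4)s3)c2)cc1`: > 20000 nM, a limit
- compound 3 `CC(=O)Nc1ccc(S(=O)(=O)Oc2cccc(/C=C(\C#N)C(=O)Nc3nnc(-c4cccs4)s3)c2)cc1`: > 20000 nM, a limit

Among the measured compounds shown here, compound 1 gives 4750 nM, the only actual number in the set. The other two readings are limits, as the limit of > 20000 nM in this assay, at which 2 of the 3 values shown sit, shows, so compound 1 cannot be ranked by size against a second number.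

Compound 4 `COc1ccc(S(=O)(=O)Oc2ccccc2/C=C(\C#N)C(=O)Nc2nnc(Cc3ccccc3)s2)cc1` keeps the core of compound 1 and carries benzyl in place of thiophen-2-yl on an aromatic carbon. For the measured compounds named here, the only measured step, a step that the two limits leave unreadable from compound 2 to compound 3, concerns acetamido in place of methyl, a different change at a different place, so it gives no size to carry over. Going by the values given here, no measured compound varies the group that changes here.

With no size to draw on, the expectation in this assay stays close to compound 1, leaning slightly towards weaker inhibition, and a limit reading is possible given (the limit of > 20000 nM in this assay, at which 2 of the 3 values shown sit). The expected change is a 1.3-fold higher number from compound 1 to compound 4 (0.10 log units; within the scatter), and it is poorly constrained. For compound 4 the estimated value is 6000 nM, with an expected range of 1800 nM to 20000 nM.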

Compound 4, half-maximal inhibitory concentration: 1060 nM
Estimate against measurement, compound 4: 5.7-fold (0.75 log units) above, outside the stated range (below it).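

In this assay, benzyl in place of thiophen-2-yl gives a 4.5-fold lower number from compound 1 to compound 4 (0.65 log units; beyond the scatter), the first readable size for a change at this position. The position, on an aromatic carbon of the five-membered aromatic ring with 2 nitrogen and 1 sulfur, therefore responds to its substituent, and benzyl is accepted there with stronger inhibition on the core of compound 1. Nothing shown gives a cause for this step.

On these data alone, it remains open whether the step follows from the methylene link of benzyl or from the six-membered ring, which phenyl attached directly or a longer chain such as 2-phenylethyl would separate. As far as these compounds go, it also remains open whether benzyl would have the same effect on the cores of compound 2 and compound 3, whose readings are limits.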